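Amino in place of methyl on the shared core

A few compounds are considered here, and "the series" means these few. Any claim that something is new, unique, unknown or untested is made for them only; others in the source may bear on it.

Compound 2 `Cc1c(C(=O)NCc2cccc(C(F)(F)F)c2)cnn1-c1ccc(Cl)cc1` gives 600 nM in a functional assay on cells for antagonist activity at C-C chemokine receptor type 1 (Homo sapiens), read by FLIPR and calcium flux; a higher number here means a weaker inhibitor, a lower number a stronger inhibitor. Among the two numbers in hand it sits beside compound 1 `Cc1c(C(=O)NCc2cccc(C(F)(F)F)c2)cnn1-c1ccc(Cl)c(Cl)c1`, which in this assay gives 500 nM; the step of a 1.2-fold higher number from compound 1 to compound 2 (0.08 log units; within the scatter) is within the scatter. For compound 3 `Cc1c(C(=O)NCc2cccc(C(F)(F)F)c2)cnn1-c1ccccc1Cl` this assay reports > 3000 nM, which is a limit and not a number. The steps of an at least 6.0-fold higher number from compound 1 to compound 3 (0.77 log units; beyond the scatter) and an at least 5.0-fold higher number from compound 2 to compound 3 (0.69 log units; beyond the scatter) are beyond the scatter, and both concern the aryl group on the ring nitrogen; one value in the set sits at a limit (the limit of > 3000 nM in this assay, at which 1 of the 3 values shown sits).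

Compound 4 `Nc1c(C(=O)NCc2cccc(C(F)(F)F)c2)cnn1-c1ccc(Cl)cc1` differs from compound 2 by amino in place of methyl on an aromatic carbon. For the measured compounds named here, none of the measured steps touches this position: all three change only the aryl group on the ring nitrogen, so they give no guide to the size or direction of this change. The expectation is therefore no step beyond the scatter, with a wide range for the lack of precedent. The estimated step is a 1.2-fold higher number from compound 2 to compound 4 (0.07 log units; within the scatter). Compound 4 is expected to give 700 nM, between 250 nM and 2000 nM.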

Compound 4, half-maximal inhibitory concentration: > 3000 nM
Compound 4: a limit, no number; the forecaster's own chance of this, stated with the estimate: 15%; middle value at least 4.2-fold (0.63 log units) away from the limit.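

Amino in place of methyl, on the aromatic carbon next to the ring atom that bears a 4-chlorophenyl group, is not a silent change in this assay: the step is an at least 5.0-fold higher number from compound 2 to compound 4 (0.69 log units; beyond the scatter). For the compounds shown here, all earlier steps changed only the aryl group on the ring nitrogen, so this is the first sign that a position on the shared core itself matters, and that exchanging a single heavy atom, carbon for nitrogen, is enough to move the result beyond the scatter. The result for compound 4 is a limit and not a number, so the true size of the step stays unread: the limit of > 3000 nM in this assay, at which 2 of the 4 values shown sit.

A hydrogen, a methoxy group or a dimethylamino group at this carbon would separate the loss of methyl from the gain of amino. As far as these compounds go, whether amino behaves the same with the 3,4-dichlorophenyl group of compound 1 on the ring nitrogen also stays open.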